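A few compounds are considered here, and "the series" means these few. Any claim that something is new, unique, unknown or untested is made for them only; others in the source may bear on it.

Measured so far:
compound 1 `Cn1cnc2c(ncn2[C@@H]2O[C@H](CO[Si](C)(C)C(C)(C)C)[C@@]3(OS(=O)(=O)C=C3N)[C@H]2O[Si](C)(C)C(C)(C)C)c1=O` gives > 150000 nM in a functional assay on MT4 cells (Homo sapiens) for cytotoxicity; a lower number here means that less compound is tolerated, a higher number that more compound is tolerated
compound 2 `COc1ncnc2c1ncn2[C@@H]1O[C@H](CO[Si](C)(C)C(C)(C)C)[C@@]2(OS(=O)(=O)C=C2N)[C@H]1O[Si](C)(C)C(C)(C)C` gives 21000 nM in this assay

Among the measured compounds shown here, compound 2 holds the only number among the two values shown; the other value is a limit. The value of compound 1 is a limit of this assay, not a number (the limit of > 150000 nM in this assay, at which 1 of the 2 values shown sits). For the measured compounds named here, the one measured step, an at least 7.1-fold lower number from compound 1 to compound 2 (0.85 log units; beyond the scatter), exchanges one methylated base for another, and it moved the number beyond the scatter.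

Compound 3, `CC(C)(C)[Si](C)(C)OC[C@H]1O[C@@H](n2cnc3ncnc(O)c32)[C@H](O[Si](C)(C)C(C)(C)C)[C@]12OS(=O)(=O)C=C2N`, differs from compound 2 by a group of 10 heavy atoms (5 carbon, 4 nitrogen, 1 oxygen; one five-membered aromatic ring with 2 hetero atoms, one six-membered aromatic ring with 2 hetero atoms) in place of a group of 11 heavy atoms (6 carbon, 4 nitrogen, 1 oxygen; one five-membered aromatic ring with 2 hetero atoms, one six-membered aromatic ring with 2 hetero atoms), on a saturated ring carbon. Going by the values given here, no measured step removes the methyl from the base, so the step from compound 1 to compound 2 bears on this change only in showing that a swap of the base can shift tolerance in this assay markedly. Compound 3 is expected to be tolerated at a higher concentration than compound 2, roughly a 3.8-fold higher number from compound 2 to compound 3 (0.58 log units; beyond the scatter). For compound 3 the estimate in this assay is 80000 nM, with a range of 20000 nM to 200000 nM, and a fair chance that only a limit is returned.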

Compound 3, half-maximal cytotoxic concentration: 15000 nM
Compound 3: the middle estimate sits 5.3-fold (0.73 log units) above what was measured, outside the stated range (below it).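

Exchanging the group of 11 heavy atoms for the group of 10 heavy atoms on the saturated ring carbon, which adds 1 hydrogen-bond donor to the base, gives a 1.4-fold lower number from compound 2 to compound 3 (0.15 log units; within the scatter) in this assay, so this change leaves the two values within the scatter. The wider contrast in the series is an at least 10-fold lower number from compound 1 to compound 3 (1.00 log units; beyond the scatter), which matches the earlier step in showing that the base of compound 1 sets it apart from both other compounds. The value of compound 1 is a limit, not a number: the limit of > 150000 nM in this assay, at which 1 of the 3 values shown sits.

From the compounds shown here alone, how a base carrying an amine or a longer chain at the same place would behave in this assay remains open. Going by these compounds, the true size of the gap to compound 1 also remains open, since only a lower bound on that step can be read.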